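This account rests on a few compounds, and the source may have more. Where it says the series, first, only, none or still open, it means among the compounds named here.

Measured compounds:
- compound 1 `O=C1Nc2ccccc2[C@]12N[C@H](c1ccccc1)[C@H](c1ccccc1)[C@@]21CCc2c([nH]c3ccccc23)C1=O` — 17000 nM in a functional assay on A549 cells (Homo sapiens) for antiproliferative activity, read by MTT assay, with a stated time of 48 h; a lower number here means a stronger inhibitor, a higher number a weaker inhibitor
- compound 2 `Cc1ccc2[nH]c3c(c2c1)CC[C@]1(C3=O)[C@@H](c2cccs2)[C@@H](c2ccccc2)N[C@@]12C(=O)Nc1ccccc12` — 15000 nM in this assay
- compound 3 `O=C1Nc2ccccc2[C@]12N[C@H](c1ccccc1)[C@H](c1cccs1)[C@@]21CCc2c([nH]c3ccc(Cl)cc23)C1=O` — 14000 nM in this assay

All three numbers sit close together. Compound 3 carries the numerically lowest of the three, but its gaps to compound 2 and to compound 1 both lie within the scatter, so no real separation among the three is shown. For the measured compounds named here, the single one-place step recorded, a 1.1-fold lower number from compound 2 to compound 3 (0.03 log units; within the scatter), stays within the scatter as well.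

Compound 4 `O=C1Nc2ccccc2[C@]12N[C@H](c1ccccc1)[C@H](c1cccs1)[C@@]21CCc2c([nH]c3ccccc23)C1=O` is the next member: hydrogen in place of chloro on an aromatic carbon. Going by the values given here, no measured step removes a substituent from that ring altogether; the closest precedent is the chloro-for-methyl exchange from compound 2 to compound 3, which changed nothing beyond the scatter. Compound 1 and compound 3 differ in two places and so only indicate that both lie in the same range. The step from compound 3 to compound 4 is therefore expected to be a 1.1-fold higher number from compound 3 to compound 4 (0.03 log units; within the scatter), no change beyond the scatter. Compound 4 is estimated at 15000 nM, with a range of 7000 nM to 32000 nM.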

Compound 4, half-maximal inhibitory concentration: 16000 nM
Estimate against measurement, compound 4: 1.1-fold (0.03 log units) below; measured number inside the range.
By their numbers in this assay, from the lowest: compounds 3, 2, 4 and 1 (each within the scatter of the next).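

In this assay, hydrogen in place of chloro on this aromatic carbon gives a 1.1-fold higher number from compound 3 to compound 4 (0.06 log units; within the scatter) and shows that the substituent can be absent altogether without a change beyond the scatter. Hydrogen in place of methyl at the same carbon gives a 1.1-fold higher number from compound 2 to compound 4 (0.03 log units; within the scatter) and completes the set, leaving hydrogen, methyl and chloro unseparated here. On the saturated ring carbon, thiophen-2-yl in place of phenyl gives a 1.1-fold lower number from compound 1 to compound 4 (0.03 log units; within the scatter) as a clean one-place reading, also without separation, so neither of the two positions varied here has yet moved the number beyond the scatter. As far as these compounds go, whether an amine or a carboxylic acid on this aromatic carbon would shift the number beyond the scatter remains open. No evidence is available to explain these flat readings.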